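A carbonyl carbon change from compound 3 to compound 4

The source may hold more compounds than are shown below. What is called first, only, known or untested is meant among the compounds shown, and "the series" means these compounds.

In a functional assay on PC-3 cells (Homo sapiens), read by MTT assay, with a stated time of 48 h (a higher number here means a weaker inhibitor, a lower number a stronger inhibitor), compound 1 `C#CCNC(=O)c1ccc(C(CC)(CC)c2ccc(OCC(O)C(C)(C)C)c(C)c2)n1CC` gives 16200 nM and compound 2 `C=CCN(C)C(=O)c1ccc(C(CC)(CC)c2ccc(OCC(O)C(C)(C)C)c(C)c2)n1CC` gives 25900 nM while compound 3 `CCn1c(C(=O)N(CCC#N)CCC#N)ccc1C(CC)(CC)c1ccc(OCC(O)C(C)(C)C)c(C)c1` gives 7800 nM as the lowest of the three numbers. Compound 4 `CC[C@@H](C)[C@H](NC(=O)c1ccc(C(CC)(CC)c2ccc(OCC(O)C(C)(C)C)c(C)c2)n1CC)C(=O)O` carries (1-carboxy-2-methylbutyl)amino on the carbonyl carbon (a group of 9 heavy atoms (6 carbon, 1 nitrogen, 2 oxygen; no ring) in place of a group of 9 heavy atoms (6 carbon, 3 nitrogen; no ring), on a carbonyl carbon). Three measured steps fall on this carbonyl carbon: a 1.6-fold higher number from compound 1 to compound 2 (0.20 log units; within the scatter) lies within the scatter while a 2.1-fold lower number from compound 1 to compound 3 (0.32 log units; beyond the scatter) and a 3.3-fold lower number from compound 2 to compound 3 (0.52 log units; beyond the scatter) are modest. Among the measured compounds shown here, compound 3 at 7800 nM sits at the low end of the measured numbers, and no measured compound carries the entering group. In this assay a modest upward step is therefore expected for compound 4 (a 2.3-fold higher number from compound 3 to compound 4 (0.36 log units; beyond the scatter)). Compound 4 is estimated at 18000 nM with 7000 nM to 50000 nM as its expected range.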

Compound 4, half-maximal inhibitory concentration: 1900 nM
The estimate for compound 4 lay 9.5-fold (0.98 log units) above the measured number, outside the stated range (below it).
By their numbers in this assay, from the lowest: compound 4; then compound 3; then compounds 1 and 2 (each within the scatter of the next).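

In this assay the (1-carboxy-2-methylbutyl)amino group on this carbonyl carbon gives the lowest number of the four compounds, with a 4.1-fold lower number from compound 3 to compound 4 (0.61 log units; beyond the scatter) and an 8.5-fold lower number from compound 1 to compound 4 (0.93 log units; beyond the scatter) and a 14-fold lower number from compound 2 to compound 4 (1.13 log units; beyond the scatter) all printed as beyond the scatter. This carbonyl carbon therefore allows a far wider span of numbers than the steps among compound 1, compound 2 and compound 3 had shown. No evidence given here accounts for the change.

The compounds shown leave open whether the carboxylic acid or the branched chain carries this drop, which a methyl ester of the same group would help separate. They also leave open whether the two defined stereocentres matter.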